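From 3-chlorophenyl to 4-bromophenyl on the amide nitrogen

The source may report more compounds than this note shows. Statements on the series, on what has been measured and on what is new or still open speak of the compounds shown alone.

Compound 1 `O=C(O)CCC(=O)OCCCCCCSc1ccc([N+](=O)[O-])c2nonc12` gives 2830 nM in a functional assay on 143B cells (Homo sapiens) for inhibition, read by MTT assay, with a stated time of 72 h (on this read-out lower numbers stand for stronger inhibition and higher numbers for weaker inhibition), and carries a hydroxy on the carbonyl carbon. Compound 2 `Cc1ccccc1NC(=O)CCC(=O)OCCCCCCSc1ccc([N+](=O)[O-])c2nonc12` gives 4660 nM with a (2-methylphenyl)amino group there. Compound 3 `O=C(CCC(=O)OCCCCCCSc1ccc([N+](=O)[O-])c2nonc12)Nc1cccc(Cl)c1` gives 2890 nM with a (3-chlorophenyl)amino group there and stands within the scatter of both other compounds. Replacing hydroxy appears as a 1.6-fold higher number from compound 1 to compound 2 (0.22 log units; within the scatter) and as a 1.0-fold higher number from compound 1 to compound 3 (0.01 log units; within the scatter) in the data. For the measured compounds named here, the closest precedent is the one exchange between two amides, which shows a 1.6-fold lower number from compound 2 to compound 3 (0.21 log units; within the scatter) and bears most directly on the next change. Compound 4 `O=C(CCC(=O)OCCCCCCSc1ccc([N+](=O)[O-])c2nonc12)Nc1ccc(Br)cc1` differs from compound 3 as 4-bromophenyl in place of 3-chlorophenyl on an amide-type nitrogen records, with 4-bromophenyl in place of 3-chlorophenyl on an amide-type nitrogen. Going by the values given here, no measured compound carries bromine. All three measured steps lie within the scatter, so no step beyond it is expected in this assay for this change. The expected step is a 1.1-fold higher number from compound 3 to compound 4 (0.04 log units; within the scatter) and would lie within the scatter. For compound 4 the estimate is 3200 nM with an expected range from 1600 nM to 6000 nM when measured.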

Compound 4, half-maximal inhibitory concentration: 2710 nM
Compound 4: the middle estimate sits 1.2-fold (0.07 log units) above what was measured; low and high end bracket the measured number.
By their numbers in this assay, from the lowest: compounds 4, 1, 3 and 2 (each within the scatter of the next).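

In this assay, the first bromine in the set, carried as 4-bromophenyl on the amide-type nitrogen, gives a step that stays within the scatter (a 1.1-fold lower number from compound 3 to compound 4 (0.03 log units; within the scatter)). The same holds against the other two compounds (a 1.7-fold lower number from compound 2 to compound 4 (0.24 log units; within the scatter); a 1.0-fold lower number from compound 1 to compound 4 (0.02 log units; within the scatter)), so all four compounds, the hydroxy compound 1 included, now lie within the scatter of one another. Nothing on hand explains this flat picture.

The step from 3-chlorophenyl to 4-bromophenyl changes both the halogen and its place on the ring, and the compounds shown do not separate the two. Also open, from the compounds shown here alone, is whether a pyridyl or benzyl group on this nitrogen, or a longer chain in the rest of the molecule, would move the number beyond the scatter.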